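This account rests on a few compounds, and the source may have more. Where it says the series, first, only, none or still open, it means among the compounds named here.

Among the compounds with values here, in an ADME assay on H9c2 cells (Rattus norvegicus) for cytotoxicity, read by MTT assay, with a stated time of 48 h (a lower number here means a stronger inhibitor, a higher number a weaker inhibitor), compound 1 `COc1ccc(NC(=S)OCCNC(=O)C(C)(C)Oc2ccc(Cl)cc2)cc1` gives 747000 nM, the only exact number available so far. Compound 2 `Cc1cnc(C(=O)OCCCOC(=O)CCCCC2CCSS2)c[n+]1[O-]` is reported only as a limit of the assay, > 800000 nM. Compound 3 `CC(C)(Oc1ccc(Cl)cc1)C(=O)NCCOC(=S)Nc1ccccc1` keeps the structure of compound 1 except for one change, hydrogen in place of methoxy on an aromatic carbon, para to a large group. Within the data shown here, no measured pair of compounds shows the effect of this change, so the expected step is a 1.1-fold lower number from compound 1 to compound 3 (0.03 log units; within the scatter), with none expected beyond the usual scatter. The estimate for compound 3 is 700000 nM, with an expected range from 300000 nM to 1200000 nM.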

Compound 3, half-maximal inhibitory concentration: > 800000 nM
Compound 3 ended at the assay's limit (the forecaster's own chance of this, stated with the estimate: 30%); middle value at least 1.1-fold (0.05 log units) from the limit.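

Swapping methoxy for hydrogen on this aromatic carbon, the change from 4-methoxyphenyl to phenyl, gives an at least 1.0-fold higher number from compound 1 to compound 3 (0.02 log units; that floor lies within the scatter) in this assay. This first pair at the position shows no move towards a lower number, but the value for compound 3 is a limit, so only a floor for the step can be given. The same limit caps most of the data: the limit of > 800000 nM in this assay, at which 2 of the 3 values shown sit.

As far as these compounds go, how far compound 3 lies past that limit stays open. So does whether an amine or a longer alkoxy chain on this carbon would give a lower number.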